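The source may report more compounds than this note shows. Statements on the series, on what has been measured and on what is new or still open speak of the compounds shown alone.

Compound 1 `CC(=O)N1CCc2nc(C#Cc3ccccc3)sc2C1` is a small amide that in an assay on HEK293 cells for negative allosteric modulation of metabotropic glutamate receptor 5 (Homo sapiens), read by FLIPR, with a stated time of 1 h (a higher number here means a weaker inhibitor, a lower number a stronger inhibitor), gives 90 nM. Compound 2 `CCC(=O)N1CCc2nc(C#Cc3ccccc3)sc2C1` gives 38 nM, and a 2.4-fold lower number from compound 1 to compound 2 (0.37 log units; beyond the scatter). Compound 3 `O=C(C1CC12CCC2)N1CCc2nc(C#Cc3ccccc3)sc2C1` carries a larger group on the carbonyl carbon, and its result in this assay, > 10000 nM, is a limit of the assay rather than a number. Compound 3 therefore stands at the limit of > 10000 nM in this assay, at which 1 of the 3 values shown sits. Even so, an at least 110-fold higher number from compound 1 to compound 3 (2.04 log units; beyond the scatter) and an at least 260-fold higher number from compound 2 to compound 3 (2.42 log units; beyond the scatter). Compound 4 `O=C(C1CCC1)N1CCc2nc(C#Cc3ccccc3)sc2C1` differs from compound 3 by a group of 4 heavy atoms (4 carbon; one four-membered non-aromatic ring of carbon only) in place of a group of 6 heavy atoms (6 carbon; one three-membered non-aromatic ring of carbon only, one four-membered non-aromatic ring of carbon only), on a carbonyl carbon; the cyclobutyl is a smaller group than the one it replaces, yet still a ring. Because the bulky group weakened binding so sharply in an at least 260-fold higher number from compound 2 to compound 3 (2.42 log units; beyond the scatter), compound 4 is expected to recover part of that loss, giving an at least 6.6-fold lower number from compound 3 to compound 4 (0.82 log units; beyond the scatter). The estimate for compound 4 is 1500 nM, within 200 nM to 10000 nM.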

Compound 4, half-maximal inhibitory concentration: 370 nM
Estimate against measurement, compound 4: 4.1-fold (0.61 log units) above; measured number inside the range.
By their numbers in this assay, from the lowest: compound 2; then compound 1; then compound 4. At a limit, above all of these: compound 3.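

Compound 3 sits at a limit of the assay, not at a number: the limit of > 10000 nM in this assay, at which 1 of the 4 values shown sits. Even so, with an at least 27-fold lower number from compound 3 to compound 4 (1.43 log units; beyond the scatter), a ring on the carbonyl carbon does not by itself carry the loss seen at that limit in this assay. Yet cyclobutyl falls short of methyl and ethyl, with a 4.1-fold higher number from compound 1 to compound 4 (0.61 log units; beyond the scatter) and a 9.7-fold higher number from compound 2 to compound 4 (0.99 log units; beyond the scatter). Still open, as far as these compounds go, is whether cyclopropyl or isopropyl on the carbonyl carbon would stand nearer to compound 2 or to compound 4. Also open, from the compounds shown here alone, is whether a longer chain such as propyl would lower the number further.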